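Furan-2-yl Replacing Methyl on the Shared Core

The source may report more compounds than this note shows. Statements on the series, on what has been measured and on what is new or still open speak of the compounds shown alone.

Compound 1 `O=C(CCCCCCc1ccccc1)c1nncs1` reaches in an assay on HEK-293T cells for inhibition of diacylglycerol lipase-alpha (Homo sapiens), read by colorimetric assay (a higher number here means a weaker inhibitor, a lower number a stronger inhibitor), only the assay limit > 10000 nM.
Compound 2 `O=C(CCCCCCc1ccccc1)c1nnn[nH]1` gives in this assay only the limit > 10000 nM; > 10000 nM (2 entries).
Compound 3 `Cn1nnc(C(=O)CCCCCCc2ccccc2)n1` gives in this assay only the limit > 10000 nM.

Compound 3 therefore stands at a limit rather than at a number, and two of the three values shown sit there (the limit of > 10000 nM in this assay, at which 2 of the 3 values shown sit). For the measured compounds named here, the single measured step that ends in compound 3, a step that the two limits leave unreadable from compound 1 to compound 3, cannot be read in size, since both of its ends are limits. Compound 4 `O=C(CCCCCCc1ccccc1)c1nnn(-c2ccco2)n1` differs from compound 3 by furan-2-yl in place of methyl on an aromatic nitrogen. Going by the values given here, no measured step bears on this change, so no direction can be drawn for this assay; the expectation is simply that compound 4 also remains near the limit. Compound 4 is estimated at 9000 nM, within 1000 nM to 50000 nM. This estimate means an expected step of an at least 1.1-fold lower number from compound 3 to compound 4 (0.04 log units; that floor lies within the scatter), not beyond the scatter.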

Compound 4, half-maximal inhibitory concentration: > 10000 nM
Compound 4 gave a limit, no number (the forecaster's own chance of this, stated with the estimate: 70%); middle value at least 1.1-fold (0.04 log units) away from the limit.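

For the compounds shown here, compound 3 and compound 4 both rest at an assay limit rather than a number, so no step between them can be read: the limit of > 10000 nM in this assay, at which 3 of the 4 values shown sit. The compounds shown leave open which change to the shared core, if any, would give a measurable number in this assay.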